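Adding a chloro group to compound 1

A few compounds are considered here, and "the series" means these few. Any claim that something is new, unique, unknown or untested is made for them only; others in the source may bear on it.

Compound 1 `Oc1ccccc1/C=N/n1cnnc1` is the starting point of this step. In a functional assay on PC-3 cells (Homo sapiens) for cytotoxicity (a higher number here means a weaker inhibitor, a lower number a stronger inhibitor), compound 1 gives > 30000 nM, which is a limit and not a number. Compound 2 `Oc1cccc(/C=N/n2cnnc2)c1O` also stops at a limit, with compound 2 at > 30000 nM in this assay. Within the data shown here, the only measured step is a step that the two limits leave unreadable from compound 1 to compound 2, with hydroxy in place of hydrogen on an aromatic carbon. All the measured evidence therefore amounts to the limit of > 30000 nM in this assay, at which 2 of the 2 values shown sit.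

Compound 3 `Oc1ccc(Cl)cc1/C=N/n1cnnc1` differs from compound 1 as follows: chloro in place of hydrogen on an aromatic carbon. In words, this is chloro in place of hydrogen on an aromatic carbon, para to a hydroxy group.

Among the measured compounds shown here, no measured step gives a size for this change. For the measured compounds named here, the one step available concerns a different group, and its size cannot be read. The working expectation in this assay is thus no step beyond the scatter, although a move toward stronger inhibition cannot be excluded. The expected step is a number no higher from compound 1 to compound 3 (the limit leaves the size open). For compound 3 the estimate is 30000 nM, with an expected range of 12000 nM to 60000 nM.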

Compound 3, half-maximal inhibitory concentration: > 30000 nM
Compound 3: only a limit was reported (the forecaster's own chance of this, stated with the estimate: 65%); the middle value sits exactly at the limit.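

No step can be read between compound 1 and compound 3, as both stop at a limit in this assay; compound 3 gives > 30000 nM, which is a limit and not a number. The compounds shown leave open whether any of these changes alters inhibition at all: the limit of > 30000 nM in this assay, at which 3 of the 3 values shown sit.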